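This account rests on a few compounds, and the source may have more. Where it says the series, first, only, none or still open, it means among the compounds named here.

Compound 3 `Nc1cc(N)c2nc(-c3ccccc3)c(NCc3ccc(F)cc3)nc2c1` is one of three close analogues of a shared core. In a functional assay on 786-0 cells (Homo sapiens) for inhibition, read by sulforhodamine B assay, with a stated time of 48 h (on this read-out higher numbers stand for weaker inhibition of growth and lower numbers for stronger inhibition of growth), compound 3 gives 61700 nM, compound 1 `Nc1cc(N)c2nc(-c3ccccc3)c(Oc3ccc(Cl)c(Cl)c3)nc2c1` gives 44700 nM, and compound 2 `COc1ccc(CNc2nc3cc(N)cc(N)c3nc2-c2ccccc2)cc1OC` gives 34700 nM. The number of compound 3 is the highest of the three, but the steps of a 1.4-fold higher number from compound 1 to compound 3 (0.14 log units; within the scatter) and a 1.8-fold higher number from compound 2 to compound 3 (0.25 log units; within the scatter) both stay within the scatter, so the three compounds cannot be ranked.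

Compound 4 `Nc1cc(N)c2nc(-c3ccccc3)c(Sc3ccc(Cl)c(Cl)c3)nc2c1` differs from compound 3 by (3,4-dichlorophenyl)sulfanyl in place of (4-fluorobenzyl)amino on an aromatic carbon. The step of a 1.4-fold higher number from compound 1 to compound 3 (0.14 log units; within the scatter) bears most directly on it, since compound 1 already carries a 3,4-dichlorophenyl group on an oxygen at the same position, and that step was small. Compound 4 is therefore expected to show no change beyond the scatter, a 1.4-fold lower number from compound 3 to compound 4 (0.14 log units; within the scatter), with an estimate of 45000 nM in this assay, ranging from 18000 nM to 110000 nM.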

Compound 4, concentration for total growth inhibition: 61700 nM
For compound 4 the middle estimate is 1.4-fold (0.14 log units) below the measured one; the range from low to high includes it.
By their numbers in this assay, from the lowest: compounds 2, 1, 3 and 4 (each within the scatter of the next).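

At this aromatic carbon next to the ring nitrogen, (3,4-dichlorophenyl)sulfanyl in place of (4-fluorobenzyl)amino gives no change at the digits printed from compound 3 to compound 4 (within the scatter) in this assay and so leaves the number within the scatter, although the entering group counts no hydrogen-bond donor and the leaving group counts one. Exchanging 3,4-dichlorophenoxy for the same sulfanyl group gives a 1.4-fold higher number from compound 1 to compound 4 (0.14 log units; within the scatter) and shows that the sulfur link also stays within the scatter of the oxygen link. Nothing available bears on why these changes leave the number in place.

On these data alone, whether a plain amine, a carboxylic acid or a longer chain at this position would move the number beyond the scatter stays open.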